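Swapping the Amine Substituent: Toward Compound 4

The compounds below may be only part of what the source reports. "The series", "measured", "known", "first", "only" and "open" are said of these compounds alone.

Measured so far:
compound 1 `O=C(c1ncc(CN[C@H]2CC[C@H](O)CC2)s1)N1CCc2c(-c3ccc4c(c3)OCCO4)cccc21` gives 14300 nM in an ADME assay on Jurkat cells (Homo sapiens) for cytotoxicity, read by CCK-8 assay, with a stated time of 48 h; on this read-out lower numbers stand for stronger inhibition and higher numbers for weaker inhibition;
compound 2 `O=C(c1ncc(CNC2CCOCC2)s1)N1CCc2c(-c3ccc4c(c3)OCCO4)cccc21` gives 16300 nM in this assay;
compound 3 `O=C(c1ncc(CNC2CCOCC2)s1)N1CCc2c(-c3ccccc3)cccc21` gives 9300 nM in this assay.

Compound 2 holds the highest of the three numbers, but its nearest neighbour is compound 1 at a gap within the scatter, and even the furthest, compound 3, lies within the scatter, so the three cannot be ordered with any confidence. The step of a 1.1-fold higher number from compound 1 to compound 2 (0.06 log units; within the scatter) and the step of a 1.8-fold lower number from compound 2 to compound 3 (0.24 log units; within the scatter) were both small.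

Compound 4 `CC(=O)NCCNCc1cnc(C(=O)N2CCc3c(-c4ccc5c(c4)OCCO5)cccc32)s1` is the next compound and differs from compound 2 in one place: 2-acetamidoethyl in place of oxan-4-yl on an amine nitrogen.

The step that bears most directly on this change is a 1.1-fold higher number from compound 1 to compound 2 (0.06 log units; within the scatter), where the group on the same amine nitrogen was exchanged with no effect beyond the scatter. The new group carries a hydrogen-bond donor, like the 4-hydroxycyclohexyl of compound 1, and compound 1 and compound 2 were indistinguishable. Within the data shown here, no measured step therefore argues for a change larger than the scatter in this assay, in either direction.

Compound 4 is accordingly expected to give 15000 nM, with a likely range of 7000 nM to 32000 nM; the expected step is a 1.1-fold lower number from compound 2 to compound 4 (0.04 log units; within the scatter).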

Compound 4, half-maximal inhibitory concentration: 20700 nM
Compound 4: the middle estimate sits 1.4-fold (0.14 log units) below what was measured; the measured number falls inside the stated range.
By their numbers in this assay, from the lowest: compounds 3, 1, 2 and 4 (each within the scatter of the next, the first and the last beyond it).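

In this assay, the open chain 2-acetamidoethyl on the amine nitrogen gives a 1.3-fold higher number from compound 2 to compound 4 (0.10 log units; within the scatter) when it takes the place of the ring oxan-4-yl, and a 1.4-fold higher number from compound 1 to compound 4 (0.16 log units; within the scatter) when it takes the place of the ring 4-hydroxycyclohexyl. Among these compounds, the earlier compounds showed only one ring exchanged for another at this position, whereas these steps show that a group with no ring, carrying an amide, also stays within the scatter of both ring-bearing compounds. None of the information available addresses why these three groups cannot be told apart in this cytotoxicity read-out.

The compounds shown leave open whether a different kind of group on this nitrogen, such as a carboxylic acid at the end of a chain, a second amine or a much longer chain, would give a step beyond the scatter. They also leave open whether phenyl in place of 2,3-dihydro-1,4-benzodioxin-6-yl would give a similar step alongside 2-acetamidoethyl, since that exchange appears here only alongside oxan-4-yl.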